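A Nitrile for an Amide on a Small Core

A few compounds are considered here, and "the series" means these few. Any claim that something is new, unique, unknown or untested is made for them only; others in the source may bear on it.

The measured compounds:
compound 1, `Cn1cc(C(N)=O)c2c(N)ncnc21`: > 100000 nM in a functional assay on KB cells (Homo sapiens) for cytotoxicity (a lower number here means a stronger inhibitor, a higher number a weaker inhibitor), which is a limit of the assay and not a number
compound 2, `CC(C)(C)c1ccc(Cn2cc(C(N)=O)c3c(N)ncnc32)cc1`: 900 nM in this assay
compound 3, `CC(C)(C)c1ccc(Cn2cc(C#N)c3c(N)ncnc32)cc1`: 3000 nM in this assay

Compound 2 and compound 3 share a core and differ in one place: cyano in place of carbamoyl on an aromatic carbon. That change gave a 3.3-fold higher number from compound 2 to compound 3 (0.52 log units; beyond the scatter), so the nitrile form is the somewhat weaker one of the pair.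

Compound 1 carries the same carbamoyl group on a core that is related to that of compound 2, but the difference between the two cores is not broken down here. On these data alone, for compound 1 the value is only a limit of the assay, (the limit of > 100000 nM in this assay, at which 1 of the 3 values shown sits), so where it truly stands is unknown.

Compound 4, `Cn1cc(C#N)c2c(N)ncnc21`, is not yet measured. It differs from compound 1 by cyano in place of carbamoyl on an aromatic carbon. This is the same kind of change as that from compound 2 to compound 3, but not the same: in compound 2 the ring atom two ring bonds from the ring nitrogen bears a large group, in compound 1 it bears a methyl group.

Among the measured compounds shown here, the only comparable step, a 3.3-fold higher number from compound 2 to compound 3 (0.52 log units; beyond the scatter), made the nitrile weaker, and compound 1 already sits at the limit. Compound 4 is therefore expected to remain at or past that limit, a step that the limit leaves unreadable from compound 1 to compound 4. The estimate for compound 4 is 300000 nM, within 100000 nM to 1000000 nM, and most likely the assay will again report only a limit.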

Compound 4, half-maximal inhibitory concentration: > 100000 nM
Compound 4: a limit, no number (the forecaster's own chance of this, stated with the estimate: 85%); the middle value is on the limit's open side.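

In this assay compound 4 gives > 100000 nM, which is a limit of the assay and not a number. Compound 1 also stands at a limit, so no step can be read between compound 1 and compound 4: the limit of > 100000 nM in this assay, at which 2 of the 4 values shown sit.

The compounds shown leave open where compound 1 and compound 4 truly stand, and whether cyano in place of carbamoyl weakens compound 4 as it weakened compound 3.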